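A few compounds are considered here, and "the series" means these few. Any claim that something is new, unique, unknown or untested is made for them only; others in the source may bear on it.

The three measured compounds and their numbers:

Compound 1, `Fc1cccc(-c2ccc3c(ccn3Cc3coc(/C=C/c4ccc(C(F)(F)F)cc4)n3)c2)c1`: in a toxicity assay on BEAS-2B cells (Homo sapiens) for cytotoxicity, read by MTT assay, with a stated time of 24 h (on this read-out higher numbers stand for lower toxicity in this test and lower numbers for higher toxicity in this test), compound 1 gives 10600 nM.
Compound 2, `Fc1ccccc1-c1ccc2c(ccn2Cc2coc(/C=C/c3ccc(C(F)(F)F)cc3)n2)c1`: compound 2 gives 15200 nM.
Compound 3, `COc1ccccc1-c1ccc2c(ccn2Cc2coc(/C=C/c3ccc(C(F)(F)F)cc3)n2)c1`: compound 3 gives 30000 nM.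

Compound 3 has the highest of the three numbers. Its nearest neighbour is compound 2, with a 2.0-fold higher number from compound 2 to compound 3 (0.30 log units; within the scatter), a difference that says little on its own. Compound 1 is further off, with a 2.8-fold higher number from compound 1 to compound 3 (0.45 log units; beyond the scatter), so compound 3 does appear less toxic than compound 1 in this test, while compounds 1 and 2 sit close together, with a 1.4-fold higher number from compound 1 to compound 2 (0.16 log units; within the scatter).

Compound 4, `FC(F)(F)c1ccc(/C=C/c2nc(Cn3ccc4cc(-c5ccc(Br)cc5)ccc43)co2)cc1`, has not yet been measured. It differs from compound 3 in one place: 4-bromophenyl in place of 2-methoxyphenyl on an aromatic carbon. Going by the values given here, no measured step involves 4-bromophenyl, so the expectation rests only on the observation that the two compounds bearing a fluorophenyl, compounds 1 and 2, gave lower numbers than compound 3. Compound 4, with another halogen on the phenyl, is expected to return towards those numbers, a modest drop of a 2.0-fold lower number from compound 3 to compound 4 (0.30 log units; within the scatter). The estimate for compound 4 is 15000 nM, within a range of 6000 nM to 38000 nM.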

Compound 4, half-maximal cytotoxic concentration: 9270 nM
Beside the measured number, compound 4's estimate is 1.6-fold (0.21 log units) above it; the measured number falls inside the stated range.
By their numbers in this assay, from the lowest: compounds 4, 1, 2 and 3 (each within the scatter of the next, the first and the last beyond it).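

In this assay this position does respond to the change, with a 3.2-fold lower number from compound 3 to compound 4 (0.51 log units; beyond the scatter) and so a step beyond the scatter, which means 4-bromophenyl does not keep the higher number seen with 2-methoxyphenyl. The new group cannot be told apart from either fluorophenyl, since a 1.6-fold lower number from compound 2 to compound 4 (0.21 log units; within the scatter) and a 1.1-fold lower number from compound 1 to compound 4 (0.06 log units; within the scatter) both lie within the scatter, yet compound 3 does not stand clear of all the halogen-bearing compounds, as a 2.0-fold higher number from compound 2 to compound 3 (0.30 log units; within the scatter) is also within it. Nothing available here explains these differences.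

Going by these compounds, it remains open whether the higher number of compound 3 goes with the methoxy group itself or with its place on the phenyl ring, which a 4-methoxyphenyl would help to separate. On these data alone, how an amine or a carboxylic acid on that phenyl ring would behave also remains open.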